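Trading a Carboxylic Acid for a Benzyl Ester

The source may hold more compounds than are shown below. What is called first, only, known or untested is meant among the compounds shown, and "the series" means these compounds.

Compound 1 `Cc1cn([C@@H]2O[C@H](CO[Si](C)(C)C(C)(C)C)[C@@]3(OS(=O)(=O)C=C3NCC(=O)O)[C@H]2O[Si](C)(C)C(C)(C)C)c(=O)n(C)c1=O` carries a carboxymethyl group on an amine nitrogen of the shared core. In a functional assay on CCRF-CEM cells (Homo sapiens) (a higher number here means that more compound is tolerated, a lower number that less compound is tolerated), compound 1 gives 65000 nM, the highest of the three measured numbers, so it is the most tolerated. Compound 2 `Cc1cn([C@@H]2O[C@H](CO[Si](C)(C)C(C)(C)C)[C@@]3(OS(=O)(=O)C=C3NC(=O)c3ccccc3)[C@H]2O[Si](C)(C)C(C)(C)C)c(=O)n(C)c1=O` gives 4910 nM, and compound 3 `Cc1cn([C@@H]2O[C@H](CO[Si](C)(C)C(C)(C)C)[C@@]3(OS(=O)(=O)C=C3NCCC(=O)O)[C@H]2O[Si](C)(C)C(C)(C)C)c(=O)n(C)c1=O` gives 19400 nM. Compound 4 `Cc1cn([C@@H]2O[C@H](CO[Si](C)(C)C(C)(C)C)[C@@]3(OS(=O)(=O)C=C3NCCC(=O)OCc3ccccc3)[C@H]2O[Si](C)(C)C(C)(C)C)c(=O)n(C)c1=O` differs from compound 1 as follows: (benzyloxycarbonyl)methyl in place of carboxy on a saturated chain carbon bound to an amine nitrogen. Going by the values given here, two measured steps bear on this change: a 13-fold lower number from compound 1 to compound 2 (1.12 log units; beyond the scatter) and a 3.4-fold lower number from compound 1 to compound 3 (0.53 log units; beyond the scatter). Both run in the same direction, and the one that brings in a benzoyl ring is the larger. A lower number is expected for compound 4 as well, with the step estimated as a 9.3-fold lower number from compound 1 to compound 4 (0.97 log units; beyond the scatter). Compound 4 is therefore estimated at 7000 nM, within a range from 2000 nM to 25000 nM.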

Compound 4, half-maximal cytotoxic concentration: > 250000 nM
Compound 4 gave a limit, no number; the forecaster's own chance of this, stated with the estimate: 5%; at least 35-fold (1.55 log units) between middle value and limit.
By their numbers in this assay, from the lowest: compound 2; then compound 3; then compound 1. At a limit, above all of these: compound 4.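

Compound 4 gave a limit, not a number: the limit of > 250000 nM in this assay, at which 1 of the 4 values shown sits. Putting benzyl on the acid gives an at least 12-fold higher number from compound 3 to compound 4 (1.11 log units; beyond the scatter), and the two other new steps run the same way: an at least 3.8-fold higher number from compound 1 to compound 4 (0.58 log units; beyond the scatter), and an at least 50-fold higher number from compound 2 to compound 4 (1.70 log units; beyond the scatter). So a benzene ring does not always go with a lower number in this assay: the benzyl ester goes up, while the benzoyl group of compound 2 went down.

From the compounds shown here alone, the true number for compound 4 stays open. So does whether a methyl ester or an amide would follow the benzyl ester.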